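The source may hold more compounds than are shown below. What is called first, only, known or untested is meant among the compounds shown, and "the series" means these compounds.

Compound 1 `COc1cc(OC)c2sc(-c3ccc(N/C=C\C(=O)c4ccc(OC)c(O)c4)cc3)nc2c1` gives 11600 nM in a functional assay on MIA PaCa-2 cells (Homo sapiens) for antiproliferative activity, read by sulforhodamine B assay, with a stated time of 48 h; on this read-out lower numbers stand for stronger inhibition and higher numbers for weaker inhibition. Compound 2 `COc1ccc(C(=O)/C=C\Nc2ccc(-c3nc4cc(OC)c(OC)c(OC)c4s3)cc2)cc1O` carries methoxy in place of hydrogen on an aromatic carbon and in this assay gives 32800 nM; the step is a 2.8-fold higher number from compound 1 to compound 2 (0.45 log units; beyond the scatter). Compound 3 `COc1ccc(C(=O)/C=C\Nc2ccc(-c3nc4cc(OC)c(OC)c(OC)c4s3)cc2)cc1[N+](=O)[O-]` gives 15900 nM, with a 2.1-fold lower number from compound 2 to compound 3 (0.31 log units; beyond the scatter). The difference between the cores of compound 1 and compound 3 is not broken down here. Compound 4 `COc1cc(C(=O)/C=C\Nc2ccc(-c3nc4cc(OC)c(OC)c(OC)c4s3)cc2)cc([N+](=O)[O-])c1OC` is not yet measured; it differs from compound 3 by methoxy in place of hydrogen on an aromatic carbon. This is the same kind of change as that from compound 1 to compound 2, but the surroundings differ: there the carbon lay in a fused system of two rings, ortho to two methoxy groups, meta and para to a fused ring; here it is ortho to one methoxy group, meta to a large group and meta to a nitro group. In this assay a step of a 1.4-fold higher number from compound 3 to compound 4 (0.14 log units; within the scatter) is expected, resting on a 2.8-fold higher number from compound 1 to compound 2 (0.45 log units; beyond the scatter) and damped for the changed surroundings. Compound 4 is expected near 22000 nM, between 9000 nM and 55000 nM.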

Compound 4, half-maximal inhibitory concentration: 15800 nM
For compound 4 the middle estimate is 1.4-fold (0.14 log units) above the measured one; the measured number falls inside the stated range.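

In this assay, methoxy in place of hydrogen on an aromatic carbon gives a 1.0-fold lower number from compound 3 to compound 4 (0.00 log units; within the scatter). The change therefore does not carry over as a fixed step between these two cores: the same change on two cores in this assay, a 2.8-fold higher number (0.45 log units; beyond the scatter) from compound 1 to compound 2 and a 1.0-fold lower number (0.00 log units; within the scatter) from compound 3 to compound 4, 2.8-fold (0.45 log units) apart, beyond the scatter of two such steps. Two pairs do not show which difference in surroundings goes with this gap, nor what step the same change would give on a further core.

Open, as far as these compounds go, is how an amine or a carboxylic acid in place of the nitro group of compound 3 would read in this assay. Also open, from the compounds shown here alone, is whether the gap between the two steps would recur on other cell lines.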